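This account rests on a few compounds, and the source may have more. Where it says the series, first, only, none or still open, it means among the compounds named here.

Going by the values given here, compound 2 `Brc1ccc(COc2nc3ccccc3s2)cc1` gives 51.9% in a functional assay on the whole organism with Mus musculus as the target, in the writhing test, at a dose of 100 mg/kg by the intraperitoneal route (a higher number here means more inhibition at the dose given (going by the name of the read-out), a lower number less inhibition), and stands lowest of the two numbers so far; compound 1 `FC(F)(F)c1ccc(COc2nc3ccccc3s2)cc1` gives 99.6%. Among the compounds with values here, the only measured step, a number 47.7 percentage points lower from compound 1 to compound 2 (beyond the scatter), shows how far a change of the group on that carbon can move the read-out. Compound 3 `Clc1ccc(COc2nc3ccccc3s2)cc1` differs from compound 2 by chloro in place of bromo on an aromatic carbon. Within the data shown here, no measured step exchanges one halogen for another, so the measured step bears on this one only by marking the same position. For compound 3 the expected step is a number 1.9 percentage points lower from compound 2 to compound 3 (within the scatter), within the scatter. Compound 3 is estimated at 50%, expected range 25% to 75%.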

Compound 3, a percentage reported as inhibition, in the whole organism at one dose (the size of the read-out at that dose, not a potency): 51.9%
Beside the measured number, compound 3's estimate is 1.9 percentage points below it; measured number inside the range.
By their numbers in this assay, from the lowest: compounds 2 and 3 (each within the scatter of the next); then compound 1.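

In this assay, exchanging bromo for chloro at this position gives no change at the digits printed from compound 2 to compound 3 (within the scatter), so these two halogens cannot be told apart here. Chloro in place of trifluoromethyl gives a number 47.7 percentage points lower from compound 1 to compound 3 (beyond the scatter), the same size as the earlier step to bromo, so the large drop now holds for both halogens. Nothing on hand accounts for the gap between trifluoromethyl and these halogens. Open, going by these compounds, is whether fluoro would read with chloro and bromo. Also open, on these data alone, is where a methoxy group, an amine or a carboxylic acid on this carbon would fall.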